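The compounds below may be only part of what the source reports. "The series", "measured", "known", "first", "only" and "open" are said of these compounds alone.

Working notes on the series. Compound 1 `COc1ccc2c(c1)c(-c1cc(C(F)(F)F)ccn1)cn2S(=O)(=O)c1ccc(C)cc1` reaches only the limit of a functional assay on A549 cells (Homo sapiens) for cytotoxicity (on this read-out higher numbers stand for weaker inhibition and lower numbers for stronger inhibition), giving > 100000 nM. For the measured compounds named here, compound 2 `Cc1ccc(S(=O)(=O)n2cc(-c3cc(C(F)(F)F)ccn3)c3ccccc32)cc1` gives 25000 nM in this assay, the only plain number in the set. The other value, that of compound 1, is a limit (the limit of > 100000 nM in this assay, at which 1 of the 2 values shown sits). The step of an at least 4.0-fold lower number from compound 1 to compound 2 (0.60 log units; beyond the scatter) shows that methoxy on the aromatic ring weakened inhibition. Compound 3 `Cc1ccc(S(=O)(=O)n2cc(-c3cc(C(F)(F)F)ccn3)c3cc(OCc4ccccc4)ccc32)cc1` differs from compound 2 by benzyloxy in place of hydrogen on an aromatic carbon. A larger ether at an aromatic carbon is expected to act like the methoxy did, so a weakening step a 3.2-fold higher number from compound 2 to compound 3 (0.51 log units; beyond the scatter) is estimated. Compound 3 is therefore expected near 80000 nM, between 25000 nM and 300000 nM.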

Compound 3, half-maximal inhibitory concentration: > 100000 nM
Compound 3 was reported as a limit; the forecaster's own chance of this, stated with the estimate: 40%; middle value at least 1.2-fold (0.09 log units) from the limit.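

In this assay, benzyloxy in place of hydrogen on this aromatic carbon gives an at least 4.0-fold higher number from compound 2 to compound 3 (0.60 log units; beyond the scatter). Both ethers shown at this carbon, methoxy and benzyloxy, therefore weaken inhibition relative to hydrogen, so the loss is not confined to methoxy. The values of compound 1 and compound 3 are both limits, so the step between them cannot be read, and the effect of the added phenyl stays unknown: the limit of > 100000 nM in this assay, at which 2 of the 3 values shown sit.

Still open, as far as these compounds go, is whether any group at this carbon improves on hydrogen. A hydroxyl, an amine or a fluorine there could fall on either side of compound 2.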